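The source may report more compounds than this note shows. Statements on the series, on what has been measured and on what is new or still open speak of the compounds shown alone.

Compound 3 `O=C(NN=C1CC(c2ccccc2)NC(c2ccccc2)C1)c1ccc(Cl)cc1` carries a 4-chlorophenyl group on its shared core. In a functional assay on A549 cells (Homo sapiens) for cytotoxicity, read by MTT assay, with a stated time of 24 h (on this read-out higher numbers stand for weaker inhibition and lower numbers for stronger inhibition), compound 3 gives > 400000 nM, which is a limit of the assay. Compound 1 `CCOC(=O)N1CCC(=NNC(=O)c2ccc(Cl)cc2)CC1` and compound 2 `CCOC(=O)N1CCC(=NNC(=O)c2ccc([N+](=O)[O-])cc2)CC1` rest on a different core but carry the same two aromatic groups. In this assay compound 1 gives > 400000 nM, a limit. In this assay compound 2 gives > 400000 nM, again a limit. All three values sit at the limit of > 400000 nM in this assay, at which 3 of the 3 values shown sit, so compound 3 stands level with the others and no number separates them. Compound 4 `O=C(NN=C1CC(c2ccccc2)NC(c2ccccc2)C1)c1ccc([N+](=O)[O-])cc1` differs from compound 3 by nitro in place of chloro on an aromatic carbon. Within the data shown here, the one measured step of this kind, a step that the two limits leave unreadable from compound 1 to compound 2, has limits at both ends and gives no readable size. Compound 4 is therefore expected to give 500000 nM, ranging from 200000 nM to 2000000 nM, which would mean an expected step that the limit leaves unreadable from compound 3 to compound 4 and no change beyond the scatter.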

Compound 4, half-maximal inhibitory concentration: > 400000 nM
Compound 4 ended at the assay's limit; the forecaster's own chance of this, stated with the estimate: 85%; the middle value is on the limit's open side.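

No step can be read from compound 3 to compound 4, since both compounds, like compound 1 and compound 2, sit at a limit: the limit of > 400000 nM in this assay, at which 4 of the 4 values shown sit.

The compounds shown leave open whether nitro in place of chloro changes the read-out in this assay on either core.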